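Pyridinylalkyl amines at the alpha4/beta2 receptor: working notes

The source may report more compounds than this note shows. Statements on the series, on what has been measured and on what is new or still open speak of the compounds shown alone.

Measured so far:
compound 1, `C[N+](C)(C)Cc1cccnc1`, 110 nM
compound 2, `C[N+](C)(C)CCC#Cc1cccnc1`, 470 nM

In an assay on brain for binding affinity to Neuronal acetylcholine receptor; alpha4/beta2 (Homo sapiens) (on this read-out lower numbers stand for stronger inhibition and higher numbers for weaker inhibition), compound 1 gives 110 nM, and compound 2 gives 470 nM. Compound 2 thus stands at the highest of the two numbers in this assay; compound 1 sits at the lower one, and the gap between the two lies beyond the scatter. The two structures differ in more than one place, so no single step can be read from them.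

Compound 3, `C(#Cc1cccnc1)CCN1CCCC1`, is not yet measured. It differs from compound 2 by a group of 5 heavy atoms (4 carbon, 1 nitrogen; one five-membered non-aromatic ring with 1 hetero atom) in place of a group of 4 heavy atoms (3 carbon, 1 nitrogen; no ring), on a saturated chain carbon, two bonds along the chain from a triple-bonded carbon. No measured step of this kind exists in the series, so the size of the change in this assay cannot be read from anything shown; the only anchor is the number for compound 2. The charged group that leaves and the ring that enters are both unexplored in this assay. The expected step from compound 2 to compound 3 in this assay is a 1.9-fold lower number from compound 2 to compound 3 (0.27 log units; within the scatter), wide rather than firm. For compound 3 in this assay the estimate is 250 nM, with a range from 50 nM to 1200 nM.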

Compound 3, inhibition constant: > 10000 nM
Compound 3 ended at the assay's limit; the forecaster's own chance of this, stated with the estimate: 5%; at least 40-fold (1.60 log units) between middle value and limit.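

In this assay, among the compounds shown here, replacing the open group with net charge +1 by pyrrolidin-1-yl, which has no net charge, on the saturated chain carbon gives an at least 21-fold higher number from compound 2 to compound 3 (1.32 log units; beyond the scatter), the first step that can be read at one place. For compound 3, the value > 10000 nM is a limit of the assay and not a number, so the step gives only a bound on the true size of the change: the limit of > 10000 nM in this assay, at which 1 of the 3 values shown sits. Compound 1 and compound 2 differ in more than one place and could not show this; the pair of compound 2 and compound 3 shows that a single exchange at this chain carbon can carry a large step.

The net charge and the ring change together in this exchange, so the compounds shown leave open which of the two carries the step. A dimethylamino group would keep the open shape without the net charge, and a methyl group added on the nitrogen of pyrrolidin-1-yl would keep the ring with the net charge, so these two groups would separate the two changes.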